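The compounds below may be only part of what the source reports. "The series", "measured", "known", "first", "only" and "open" are said of these compounds alone.

Measured in a functional assay on HepG2 cells (Homo sapiens) for cytotoxicity, read by MTT assay, with a stated time of 48 h; a higher number here means a weaker inhibitor, a lower number a stronger inhibitor:
- Compound 1 `O=C(CSc1nnc(-c2ccncc2)o1)N/N=C/c1ccccc1`: 17300 nM
- Compound 2 `O=C(CSc1nnc(-c2ccncc2)o1)N/N=C/c1ccc(Br)cc1`: 18600 nM
- Compound 3 `O=C(CSc1nnc(-c2ccncc2)o1)N/N=C/c1ccc(O)cc1`: 5510 nM

Compound 3 has the lowest number of the three, and its steps to both compound 1 and compound 2 lie beyond the scatter. The next compound, compound 4 `Cc1ccc(/C=N/NC(=O)CSc2nnc(-c3ccncc3)o2)cc1`, has not yet been measured. It differs from compound 3 at one place: methyl in place of hydroxy on an aromatic carbon. This is methyl in place of hydroxy on an aromatic carbon, para to a large group, so that 4-hydroxyphenyl becomes 4-methylphenyl.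

Among the compounds with values here, no methyl compound has been measured, so the evidence is indirect. Hydroxy in place of hydrogen gave a 3.1-fold lower number from compound 1 to compound 3 (0.50 log units; beyond the scatter), and hydroxy in place of bromo gave a 3.4-fold lower number from compound 2 to compound 3 (0.53 log units; beyond the scatter). Both are modest steps. Bromo in place of hydrogen gave a 1.1-fold higher number from compound 1 to compound 2 (0.03 log units; within the scatter), so the two compounds without hydroxy, compound 1 and compound 2, do not differ beyond the scatter. Compound 4 also lacks the hydroxy, so it is expected to lie near those two, though somewhat uncertainly. In this assay, the expected change is a 2.5-fold higher number from compound 3 to compound 4 (0.40 log units; beyond the scatter), a modest step towards a higher number. For compound 4, the estimated value is 14000 nM, with an expected range of 6000 nM to 30000 nM.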

Compound 4, half-maximal inhibitory concentration: 10000 nM
Compound 4: middle estimate off by 1.4-fold (0.15 log units), on the high side; the measured number falls inside the stated range.
By their numbers in this assay, from the lowest: compounds 3, 4, 1 and 2 (each within the scatter of the next, the first and the last beyond it).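

In this assay the methyl group places compound 4 within the scatter of all three earlier compounds (a 1.8-fold higher number from compound 3 to compound 4 (0.26 log units; within the scatter)) (a 1.7-fold lower number from compound 1 to compound 4 (0.24 log units; within the scatter)) (a 1.9-fold lower number from compound 2 to compound 4 (0.27 log units; within the scatter)). The earlier compounds shown here alone suggested a simple split at this position, para to a large group, with hydroxy standing apart from hydrogen and bromo by steps beyond the scatter, but compound 4 goes against that split: it has no hydroxy, yet it cannot be separated from compound 3, nor from compound 1 or compound 2. Hydroxy therefore no longer stands clearly apart from every other group tried here, and no measured property of these groups is available to account for the result.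

From the compounds shown here alone, it remains open whether an amine, a methoxy group or a carboxylic acid in this place would fall with compound 3 or with compound 1 and compound 2. Going by these compounds, it is also open whether the small differences seen here would hold in cells other than those of this assay, or with the group placed elsewhere on the same aromatic ring.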